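The source may report more compounds than this note shows. Statements on the series, on what has been measured and on what is new or still open speak of the compounds shown alone.

Measured in an ADME assay on HEK293 cells (Homo sapiens) for cytotoxicity, read by WST assay; a higher number here means that more compound is tolerated, a lower number that less compound is tolerated:
- compound 1 `CC(C)(C)c1cccc(C(=O)OCc2ccc(C=O)cc2)c1`: 73000 nM
- compound 2 `O=C(OCc1ccc(B(O)O)cc1)c1cc(C(F)(F)F)cc(C(F)(F)F)c1`: 49000 nM

Compound 2 at 49000 nM and compound 1 at 73000 nM lie within the scatter of each other, so compound 2 does not stand apart on these numbers. Going by the values given here, the two compounds differ in more than one place, and no measured pair isolates a single change.

Compound 3 `O=C(O)c1ccc(COC(=O)c2cc(C(F)(F)F)cc(C(F)(F)F)c2)cc1` has not yet been measured in this assay. Relative to compound 2, it carries carboxy in place of a group of 3 heavy atoms (1 boron, 2 oxygen; no ring), on an aromatic carbon, para to a large group: a group of 3 heavy atoms (1 carbon, 2 oxygen; no ring) in place of a group of 3 heavy atoms (1 boron, 2 oxygen; no ring), on an aromatic carbon.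

The estimated step of a 1.2-fold higher number from compound 2 to compound 3 (0.09 log units; within the scatter) is expected to stay within the scatter, with no firm direction. For compound 3 the expected value is 60000 nM, with an estimated range of 25000 nM to 140000 nM.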

Compound 3, half-maximal cytotoxic concentration: > 100000 nM
Compound 3: a limit, no number (the forecaster's own chance of this, stated with the estimate: 25%); middle value at least 1.6-fold (0.22 log units) away from the limit.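

Compound 3 gives > 100000 nM in this assay, a limit of the assay and not a number. Going by these compounds alone, this is the first change confined to one place: carboxy on the aromatic carbon, para to a large group, replaces the boron-containing group, giving an at least 2.0-fold higher number from compound 2 to compound 3 (0.30 log units; that floor lies within the scatter). The step is therefore a floor that lies within the scatter, so it shows no firm difference between the two groups at this position, and its true size remains unknown upward: the limit of > 100000 nM in this assay, at which 1 of the 3 values shown sits.

Open, from the compounds shown here alone, is how far compound 3 really lies from compound 2, which a value below the limit would be needed to settle. Also open, going by these compounds, is whether an amine or a primary amide at this position would read like carboxy or like the boron-containing group.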